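A Bromo-for-Fluoro Swap on a Shared Core

This account rests on a few compounds, and the source may have more. Where it says the series, first, only, none or still open, it means among the compounds named here.

Compound 1 `COc1cc2c(Nc3ccc(F)c(Cl)c3F)ncnc2c(OC)c1OC` was tested in a functional assay on SGC-7901 cells (Homo sapiens) for antiproliferative activity, read by MTT assay, with a stated time of 72 h; on this read-out higher numbers stand for weaker inhibition and lower numbers for stronger inhibition. In this assay compound 1 gives only a limit of > 30000 nM, not a number. Compound 2 `COc1cc2c(Nc3cccc(Br)c3F)ncnc2c(OC)c1OC` carries a different halogen pattern on the same ring of the same core. In this assay compound 2 likewise gives only a limit, > 30000 nM. Both values sit at the same boundary (the limit of > 30000 nM in this assay, at which 2 of the 2 values shown sit), so neither compound shows measurable inhibition within the tested range. For the measured compounds named here, no step between the two measured compounds can be drawn from two limits; they show only that both lie beyond what this assay resolves.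

Compound 3 `COc1cc2c(Nc3ccc(Br)c(Cl)c3F)ncnc2c(OC)c1OC` differs from compound 1 by bromo in place of fluoro on an aromatic carbon. The step from compound 1 to compound 3 is expected to be a step that the limit leaves unreadable from compound 1 to compound 3, which amounts to no change beyond the scatter, since the starting point itself sits at the limit (the limit of > 30000 nM in this assay, at which 2 of the 2 values shown sit). Compound 3 is therefore expected to give about 40000 nM in this assay, within a range from 15000 nM to 120000 nM, and most probably only a limit again.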

Compound 3, half-maximal inhibitory concentration: 15000 nM
Beside the measured number, compound 3's estimate is 2.7-fold (0.43 log units) above it, and the stated range covers the measured number.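

For the compounds shown here, with bromo in place of fluoro on the aromatic carbon ortho to a chloro group, compound 3 gives 15000 nM in this assay, the first value in this set that is a number and not a limit, so this position can carry a change that brings inhibition into the range the assay resolves. As far as these compounds go, the swap gives an at least 2.0-fold lower number from compound 1 to compound 3 (0.30 log units; that floor lies within the scatter), and this figure is only a floor, so the true size of the step remains unknown and the printed minimum alone does not set it apart from ordinary scatter. The step cannot be pinned down any further because its starting point, compound 1, stands at a limit: the limit of > 30000 nM in this assay, at which 2 of the 3 values shown sit.

The compounds shown leave open whether a different group on this carbon, such as iodo, methyl, methoxy or an amine, would lower the number further or return it to the limit. They also leave open whether the bromo would give a readable value if the chloro group on the same ring were replaced by hydrogen or by a methyl group.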